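A few compounds are considered here, and "the series" means these few. Any claim that something is new, unique, unknown or untested is made for them only; others in the source may bear on it.

Measured so far:
- compound 1 `CC1=NN(C(=O)c2ccccc2)C(c2ccccc2O)C1`: 30900 nM
- compound 2 `CC1=NN(C(=O)c2ccc(C)cc2)C(c2ccccc2O)C1`: 116000 nM

In a functional assay on PC-3 cells (Homo sapiens) for cytotoxicity, read by MTT assay, with a stated time of 48 h (a lower number here means a stronger inhibitor, a higher number a weaker inhibitor), compound 2 gives 116000 nM, the higher of the two numbers and therefore the weaker result of the pair. Compound 3 `CC1=NN(C(=O)c2ccccc2C)C(c2ccccc2O)C1` has the same atoms as compound 2, joined differently: 2-methylphenyl in place of 4-methylphenyl on a carbonyl carbon. In words, it has 2-methylphenyl in place of 4-methylphenyl on a carbonyl carbon.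

Among the compounds with values here, only one measured step bears on this change: a 3.8-fold higher number from compound 1 to compound 2 (0.57 log units; beyond the scatter). It is modest, and it comes from methyl in place of hydrogen on an aromatic carbon. Within the data shown here, no measured compound carries 2-methylphenyl, so this single step is a weak guide. It gives the scale of change seen so far in this small series, and compound 1 at 30900 nM offers the only lower reference point. A modest move toward a lower number in this assay is therefore expected, although a result within the scatter of compound 2 would not be surprising. The expected change is a 1.8-fold lower number from compound 2 to compound 3 (0.25 log units; within the scatter). For compound 3 the estimated value is 65000 nM, with an expected range of 22000 nM to 190000 nM.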

Compound 3, half-maximal inhibitory concentration: 106000 nM
Compound 3: the middle estimate sits 1.6-fold (0.21 log units) below what was measured, within the range that was stated.
By their numbers in this assay, from the lowest: compound 1; then compounds 3 and 2 (each within the scatter of the next).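

In this assay, moving the methyl from 4-methylphenyl to 2-methylphenyl on a carbonyl carbon gives a 1.1-fold lower number from compound 2 to compound 3 (0.04 log units; within the scatter), so this read-out does not separate the two isomers. Compared with the unsubstituted phenyl of compound 1, the 2-methylphenyl group gives a 3.4-fold higher number from compound 1 to compound 3 (0.54 log units; beyond the scatter), so the shift seen earlier as a 3.8-fold higher number from compound 1 to compound 2 (0.57 log units; beyond the scatter) is not confined to 4-methylphenyl and appears with both methyl placements shown. No accompanying measurement offers an explanation for these numbers.

The compounds shown leave open whether this shift is specific to methyl or extends to other groups on this phenyl, and whether a methoxy group, a fluorine atom or an amine would give a lower number than compound 1, at 30900 nM. From the compounds shown here alone, with only one cell line in view, it also remains open whether the same grouping of compound 1 apart from compound 2 and compound 3 would hold in other cells.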